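Replacing a Methyl with an Oxazole on the Amide Carbonyl

A few compounds are considered here, and "the series" means these few. Any claim that something is new, unique, unknown or untested is made for them only; others in the source may bear on it.

Measured so far in a functional assay (Sus scrofa) with sulfonylurea receptors; K-ATP channels (Homo sapiens) as the target; on this read-out lower numbers stand for smaller maximal responses and higher numbers for larger maximal responses:
Compound 1, `CC(=O)Nc1c(C(O)(C(F)(F)F)C(F)(F)F)ccc2ccccc12`, gives 87%.
Compound 2, `CC(C)=CC(=O)Nc1c(C(O)(C(F)(F)F)C(F)(F)F)ccc2ccccc12`, gives 96%.
Compound 3, `O=C(Nc1c(C(O)(C(F)(F)F)C(F)(F)F)ccc2ccccc12)c1cccc(Cl)c1`, gives 84%.

All three compounds share one core and differ only in the group on the amide carbonyl. Compound 1, with the smallest group there, sits among the other two: its separation from compound 3 and from compound 2 each lies within the usual scatter, so none of the three can be called stronger or weaker than another with confidence.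

Compound 4, `O=C(Nc1c(C(O)(C(F)(F)F)C(F)(F)F)ccc2ccccc12)c1cnco1`, is the next member and is still to be measured. It differs from compound 1 by 1,3-oxazol-5-yl in place of methyl on a carbonyl carbon.

Two measured steps speak to this change, since both also swap the methyl for a larger group on the same carbonyl: a number 9 percentage points higher from compound 1 to compound 2 (within the scatter) and a number 3 percentage points lower from compound 1 to compound 3 (within the scatter). Neither moved the response beyond the scatter. Between the two larger groups the difference was modest: a number 12 percentage points lower from compound 2 to compound 3 (beyond the scatter). Since an aromatic ring on the carbonyl, as in compound 3, left the response close to that of compound 1, a ring of another kind is expected to do much the same, giving no step beyond the scatter: a number 1 percentage points lower from compound 1 to compound 4 (within the scatter).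

For compound 4 the estimated response is therefore 86%, expected to fall between 72% and 98%.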

Compound 4, largest response reached (reported as efficacy), in percent of the reference or control that the assay uses: 97%
For compound 4 the middle estimate is 11 percentage points below the measured one; low and high end bracket the measured number.
By their numbers in this assay, from the lowest: compounds 3, 1, 2 and 4 (each within the scatter of the next, the first and the last beyond it).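

In this assay the 1,3-oxazol-5-yl group shows that the kind of ring on this carbonyl carbon can matter, since the two ring-bearing compounds are separated beyond the scatter (a number 13 percentage points higher from compound 3 to compound 4 (beyond the scatter)), a modest gap that compound 3 alone could not reveal. Measured against the two compounds without a ring on the carbonyl, the new group stays within the scatter (a number 10 percentage points higher from compound 1 to compound 4 (within the scatter); a number 1 percentage points higher from compound 2 to compound 4 (within the scatter)), so this five-membered aromatic ring is accepted here with the maximal response still not separable from that of the methyl or 2-methylprop-1-en-1-yl compound. No measurement at hand explains why the two rings part in this way.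

The compounds shown leave open what separates the 3-chlorophenyl from the 1,3-oxazol-5-yl group, whether the chlorine, the ring size or the ring nitrogen and oxygen, as these differ together between the two compounds. They also leave open how the response would behave with a quite different group on the same carbonyl, such as an amine, a carboxylic acid or a longer carbon chain.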